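Shortening the acyl chain by one carbon

A few compounds are considered here, and "the series" means these few. Any claim that something is new, unique, unknown or untested is made for them only; others in the source may bear on it.

Compound 1, `CCCCCCCCC(=O)N1c2ccccc2CCC1C(=O)Nc1ccccc1O`, gives 31100 nM in a functional assay on NUGC-3 cells (Homo sapiens) for cytotoxicity, read by sulforhodamine B assay, with a stated time of 72 h; a lower number here means a stronger inhibitor of growth, a higher number a weaker inhibitor of growth.
Compound 2, `CCCC(=O)N1c2ccccc2CCC1C(=O)Nc1cc(C(F)(F)F)cc(C(F)(F)F)c1`, gives 14400 nM in this assay.
Compound 3, `O=C(Nc1ccccc1C(F)(F)F)C1CCc2ccccc2N1C(=O)c1ccc(Cl)cc1`, gives 551 nM in this assay.

Among these three, compound 2 holds the second highest number: compound 1 sits above it by a gap beyond the usual scatter, and compound 3 sits far below it, also beyond the scatter. The two outer compounds differ from compound 2 in more than one place, so their values speak only for themselves.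

Compound 4, `CCC(=O)N1c2ccccc2CCC1C(=O)Nc1cc(C(F)(F)F)cc(C(F)(F)F)c1`, has not yet been measured in this assay. It differs from compound 2 in a single spot: hydrogen in place of methyl on a saturated chain carbon, two bonds along the chain from a carbonyl carbon. This is a modest trimming of the saturated chain on the nitrogen-bound carbonyl, leaving everything else untouched. Nothing measured here isolates this kind of one-carbon change, so the expected step from compound 2 to compound 4 is small, a 1.2-fold lower number from compound 2 to compound 4 (0.08 log units; within the scatter), and likely within the scatter. Compound 4 is therefore estimated at 12000 nM, with a range from 5000 nM to 30000 nM.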

Compound 4, concentration for 50% growth inhibition: 7220 nM
Compound 4: the middle estimate sits 1.7-fold (0.22 log units) above what was measured; the measured number falls inside the stated range.
By their numbers in this assay, from the lowest: compound 3; then compounds 4 and 2 (each within the scatter of the next); then compound 1.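

In this assay, replacing the propylcarbonyl group with propanoyl gives a 2.0-fold lower number from compound 2 to compound 4 (0.30 log units; within the scatter). Going by these compounds alone, this is the first pair here that differs in only one place, and it shows that removing this one chain carbon, with everything else held fixed, produces no change that can be told apart from the scatter. On this evidence, the saturated chain carbon two bonds along from the carbonyl carbon can lose its methyl without a clear effect on growth inhibition in these cells, at least for this pair. Nothing available here explains the size of this step.

From the compounds shown here alone, it remains open whether a longer chain, such as hexanoyl, or a chain ending in an amine or a carboxylic acid would also leave the number unchanged. Within the data shown here, the same trimming might also behave differently on another amide, such as the one in compound 1.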